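This account rests on a few compounds, and the source may have more. Where it says the series, first, only, none or still open, it means among the compounds named here.

Of the compounds shown here, two of one shared core have been tested in a functional assay on HEK293 cells for agonist activity at Bombesin receptor subtype-3 (Mus musculus), read by luminescence and calcium flux, with a stated time of 10 min; a lower number here means that less compound is needed, a higher number that more compound is needed for the effect. Compound 1 `CCC(C)(C)Cc1c[nH]c(CCc2ccc(-c3ccncc3)cc2)n1` gives 15 nM, the lowest of the two numbers seen so far. Compound 2 `CCC(C)(C)Cc1c[nH]c(CCc2ccc(-n3ccnn3)cc2)n1`, whose only difference is the 1H-1,2,3-triazol-1-yl in place of pyridin-4-yl on an aromatic carbon, gives 57 nM; that change is a 3.8-fold higher number from compound 1 to compound 2 (0.58 log units; beyond the scatter).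

Compound 3 `CCC(C)(C)Cc1c[nH]c(CCc2ccc(-n3cncn3)cc2)n1` has not yet been measured in this assay . It differs from compound 1 in one place only: 1H-1,2,4-triazol-1-yl in place of pyridin-4-yl on an aromatic carbon. Within the data shown here, the change is a close cousin of the one that separates compound 1 from compound 2, since in both cases a five-membered ring with three hetero atoms replaces the six-membered pyridin-4-yl ring. Among the measured compounds shown here, the only measured step that bears on it, from compound 1 to compound 2, was modest but beyond the scatter. A step of similar size, towards a higher number, is therefore expected from compound 1 to compound 3, although the two triazoles are not identical and the exact size is open.

On that basis compound 3 is expected to give about 45 nM in this assay , within a range from 15 nM to 140 nM, a step of a 3.0-fold higher number from compound 1 to compound 3 (0.48 log units; beyond the scatter) that is expected.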

Compound 3, half-maximal effective concentration: 12 nM
Beside the measured number, compound 3's estimate is 3.8-fold (0.57 log units) above it; measured number below the stated range.
By their numbers in this assay, from the lowest: compounds 3 and 1 (each within the scatter of the next); then compound 2.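

In this assay, the step from pyridin-4-yl to 1H-1,2,4-triazol-1-yl is a 1.3-fold lower number from compound 1 to compound 3 (0.10 log units; within the scatter), so at this position a five-membered aromatic ring with three hetero atoms can replace the six-membered ring without a change that stands out from the scatter. The two triazoles, however, are not interchangeable, even though they share a ring size and the same atoms and differ only in how those atoms are arranged: exchanging one for the other gives a 4.8-fold lower number from compound 2 to compound 3 (0.68 log units; beyond the scatter). The higher number of compound 2 therefore belongs to 1H-1,2,3-triazol-1-yl in particular and not to triazole rings in general, though no measurement at hand offers a reason for the gap between the two.

The compounds shown leave open how other groups would behave at this position, such as a tetrazole ring, a plain phenyl ring or a carboxylic acid. They also leave open whether the gap between the two triazoles would persist if the branched alkyl chain on the shared core were replaced by a different group.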